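This account rests on a few compounds, and the source may have more. Where it says the series, first, only, none or still open, it means among the compounds named here.

Compound 1 `CS(=O)(=O)c1ccc(-c2ccc3ncnc(Nc4ccc(OCc5cccc(F)c5)c(Cl)c4)c3c2)cc1` in an ADME assay on HepG2 cells (Homo sapiens) for cytotoxicity, read by MTT assay, with a stated time of 48 h (a lower number here means a stronger inhibitor, a higher number a weaker inhibitor), gives > 15000 nM, a limit of the assay rather than a number.
Compound 2 `O=S(=O)(c1ccc(-c2ccc3ncnc(Nc4ccc(OCc5cccc(Br)c5)c(Cl)c4)c3c2)cc1)N1CCOCC1` in this assay gives > 15000 nM, likewise a limit of the assay.

Among the compounds with values here, compound 2 therefore stands at the edge of what this assay reports: its value is a limit, and the only other value shown is a limit as well, so the limit of > 15000 nM in this assay, at which 2 of the 2 values shown sit, is all that the measured compounds tell. Within the data shown here, no step between two measured compounds is available, and nothing in the numbers separates compound 1 from compound 2.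

Compound 3 `O=S(=O)(c1ccc(-c2ccc3ncnc(Nc4ccc(OCc5cc(F)cc(F)c5F)c(Cl)c4)c3c2)cc1)N1CCOCC1` has not yet been measured in this assay. It differs from compound 2 in one place, (2,3,5-trifluorophenyl in place of 3-bromophenyl on a saturated chain carbon bound to an oxygen on an aromatic ring). Among the measured compounds shown here, since both measured compounds sit at the same limit and no measured step exists, the change is expected to produce no step beyond the usual scatter, and the step that is expected is a step that the limit leaves unreadable from compound 2 to compound 3. Compound 3 is accordingly estimated at 20000 nM, with a range from 10000 nM to 40000 nM, and it is expected that this assay will most likely again report only a limit for compound 3.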

Compound 3, half-maximal inhibitory concentration: > 3000 nM
Compound 3: no number, only a limit (the forecaster's own chance of this, stated with the estimate: 80%); the middle value lies beyond the limit too.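

Within the data shown here, compound 2 and compound 3 both stand at limits of this assay rather than at numbers, so no step between them can be read. The compounds shown leave open where the actual values of compound 1, compound 2 and compound 3 lie, and whether 2,3,5-trifluorophenyl in place of 3-bromophenyl changes anything at all.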